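Pyridinylmethyl in Place of Pyrazinyl on the Amide Nitrogen

The source may report more compounds than this note shows. Statements on the series, on what has been measured and on what is new or still open speak of the compounds shown alone.

Of the compounds shown here, two sharing one core have so far been measured in a functional assay on the whole organism for inhibition, with Rattus norvegicus as the target, read by cytopathic effect and paw edema, at a dose of 100 mg/kg by the oral route; on this read-out lower numbers stand for less inhibition and higher numbers for more inhibition at the one dose given (going by the name of the read-out). Compound 1 `O=C(Nc1ccccc1)c1c(O)c2cccnc2n(-c2ccccc2)c1=O` gives -15% in this assay. Among the measured compounds shown here, compound 2 `O=C(Nc1cnccn1)c1c(O)c2cccnc2n(-c2ccccc2)c1=O` gives 21.2% in this assay, the higher of the two numbers, with compound 1 as its only neighbour. For the measured compounds named here, the single measured step is a number 36.2 percentage points higher from compound 1 to compound 2 (beyond the scatter), and it reaches well beyond the scatter.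

Compound 3 `O=C(NCc1ccncc1)c1c(O)c2cccnc2n(-c2ccccc2)c1=O` has not yet been measured. It differs from compound 2 by (pyridin-4-yl)methyl in place of pyrazin-2-yl on an amide-type nitrogen. Going by the values given here, the one measured step bears on it only in part: it altered the group on the same amide-type nitrogen and shows that this position can move the read-out a great deal, but it went from phenyl to pyrazin-2-yl, whereas the present change goes from pyrazin-2-yl to (pyridin-4-yl)methyl, a pair no measured compounds cover. Among the compounds with values here, with no direct precedent, a step of a number 13.2 percentage points lower from compound 2 to compound 3 (beyond the scatter) is expected, a moderate fall with wide uncertainty. Compound 3 is therefore estimated at 8%, most likely between -18% and 32%.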

Compound 3, a percentage reported as inhibition, in the whole organism at one dose (the size of the read-out at that dose, not a potency): 15.4%
Compound 3: the middle estimate sits 7.4 percentage points below what was measured, and the stated range covers the measured number.
By their numbers in this assay, from the lowest: compound 1; then compounds 3 and 2 (each within the scatter of the next).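

In this assay, the change from pyrazin-2-yl to (pyridin-4-yl)methyl on the amide-type nitrogen gives a number 5.8 percentage points lower from compound 2 to compound 3 (within the scatter), so the two groups cannot be told apart on this read-out, even though the entering group has one ring nitrogen fewer and a methylene link that the leaving group lacks. The second new step, a number 30.4 percentage points higher from compound 1 to compound 3 (beyond the scatter), shows that the gain over phenyl seen in a number 36.2 percentage points higher from compound 1 to compound 2 (beyond the scatter) is not particular to pyrazin-2-yl: among these three compounds, both groups with a ring nitrogen stand clear of phenyl, whether the ring sits directly on the amide-type nitrogen or one carbon away from it. No data bear on why these groups behave alike at this position.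

The compounds shown leave open whether the ring nitrogen or the methylene link matters more, a question that benzyl on the same nitrogen, or (pyridin-2-yl)methyl and (pyridin-3-yl)methyl, would address. They also leave open whether an aromatic ring is needed here at all, as against a morpholine, a short alkyl chain bearing an amine, or a carboxylic acid.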